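Swapping an Aromatic Group on a Shared Core

The source may report more compounds than this note shows. Statements on the series, on what has been measured and on what is new or still open speak of the compounds shown alone.

Of the compounds shown here, three built on one shared core have been measured so far. Compound 1 `CC[C@@H](Nc1c(C#N)c(-c2ccc(-c3cccnc3C)cc2)nc2cnccc12)C(N)=O` gives 1.9 in a physicochemical assay for lipophilicity, read by HPLC, at pH 7.5; a lower number here means a more polar compound, a higher number a more lipophilic compound. Compound 2 `N#Cc1c(-c2ccc(Br)cc2)nc2cnccc2c1NCC(N)=O` gives 1.9 in this assay, and compound 3 `CC(Nc1c(C#N)c(-c2ccc(Br)cc2)nc2cnccc12)C(N)=O` gives 2.1. Compound 1 thus stands level with compound 2 at the digits shown, the two together being the lowest of the three numbers, while the number for compound 3 is a little higher than that of compound 1, by an amount that stays within the usual scatter.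

Among the compounds with values here, the only step measured so far between two compounds differing in one place is a number 0.20 log units higher from compound 2 to compound 3 (within the scatter), where a methyl replaces a hydrogen on a saturated chain carbon bound to a carbonyl carbon and a nitrogen on an aromatic ring.

Compound 4 `CC[C@@H](Nc1c(C#N)c(-c2ccc(-c3cccc(CO)c3)cc2)nc2cnccc12)C(N)=O` differs from compound 1 in another place entirely: 3-(hydroxymethyl)phenyl in place of 2-methylpyridin-3-yl on an aromatic carbon

Within the data shown here, no measured step concerns a change of this kind, so the measured data give no direct guide. The group that leaves and the group that enters each carry one hydrogen-bond acceptor, and the entering group adds one hydrogen-bond donor. The expectation is therefore a small step, a number 0.10 log units higher from compound 1 to compound 4 (within the scatter), not beyond the scatter. Compound 4 is estimated at 2 in this assay, within a range from 1.5 to 2.5.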

Compound 4, distribution coefficient: 2
Beside the measured number, compound 4's estimate shows no gap at the digits printed; the range from low to high includes it.
By their numbers in this assay, from the lowest: compounds 1, 2, 4 and 3 (each within the scatter of the next).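

Within the data shown here, the first step at this place, on an aromatic carbon para to a large group, is a number 0.10 log units higher from compound 1 to compound 4 (within the scatter) in this assay; the earlier step concerned only a methyl on the saturated chain. Here a larger exchange, from a ring with one hetero atom and no hydrogen-bond donor to a ring of carbon only whose hydroxymethyl group carries one, still leaves the two numbers within the scatter of each other. This single pair therefore shows that this place can take either 2-methylpyridin-3-yl or 3-(hydroxymethyl)phenyl with no change in this read-out that can be told from scatter, and nothing available explains why the two numbers lie so close.

Whether a ring carrying an amine or a carboxylic acid at this place would also stay within the scatter remains open, since both groups shown here have no net charge. Also open, as far as these compounds go, is whether the methyl step on the chain, seen with the bromine-bearing compounds, would look the same with either of these two larger aromatic groups in place.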